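Cytotoxicity notes: methyl for methoxy on the aryl ring

The source may report more compounds than this note shows. Statements on the series, on what has been measured and on what is new or still open speak of the compounds shown alone.

Measured compounds:
compound 1 `COc1ccc(-n2c(=O)n(Cc3cc4cc(Cl)ccc4n3CCCC#N)c3cnccc32)cc1` — > 50000 nM
compound 2 `O=c1n(Cc2cc3cc(Cl)ccc3n2CCCC(F)(F)F)c2cnccc2n1C1CC1` — > 50000 nM

In an ADME assay on HeLa cells (Homo sapiens) for cytotoxicity, read by ATP content, with a stated time of 3 days (on this read-out lower numbers stand for higher toxicity in this test and higher numbers for lower toxicity in this test), compound 1 gives > 50000 nM, which is a limit of the assay and not a number. Compound 2 gives > 50000 nM in this assay, also a limit. Both shown values sit at the limit of > 50000 nM in this assay, at which 2 of the 2 values shown sit, so no step between measured compounds can be computed, and compound 1 stands only at that limit with nothing to rank it against. Compound 3 `Cc1ccc(-n2c(=O)n(Cc3cc4cc(Cl)ccc4n3CCCC#N)c3cnccc32)cc1` is not yet measured in this assay. It differs from compound 1 by methyl in place of methoxy on an aromatic carbon. With every measured compound at the limit, no step beyond the scatter is expected in this assay, and the expected change is a step that the limit leaves unreadable from compound 1 to compound 3. Compound 3 is estimated at 60000 nM, with a range of 20000 nM to 200000 nM, most likely reported again as a limit.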

Compound 3, half-maximal cytotoxic concentration: > 50000 nM
Compound 3: a limit, no number; the forecaster's own chance of this, stated with the estimate: 85%; the middle value is on the limit's open side.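

Among the compounds shown here, compound 1 and compound 3 both stand only as limits in this assay, so no step between them can be read: the limit of > 50000 nM in this assay, at which 3 of the 3 values shown sit. Left open is whether 4-methoxyphenyl and 4-methylphenyl differ at all in half-maximal cytotoxic concentration, and at what concentration any of the three compounds would become toxic to these cells.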